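Allyl to Neopentyl on a Shared Pyrrolopyrimidine-Type Core

The source may hold more compounds than are shown below. What is called first, only, known or untested is meant among the compounds shown, and "the series" means these compounds.

Measured so far:
- compound 1, `Cc1nc2nccc-2c(Nc2ccc(C(C)C)cc2)[nH]1`: 45700000 nM
- compound 2, `C=CCNc1nc(C)nc2[nH]ccc12`: 676000000 nM

Two compounds have numbers in a functional assay on the whole organism for inhibition, with Nicotiana tabacum as the target; a higher number here means a weaker inhibitor, a lower number a stronger inhibitor. Compound 1, `Cc1nc2nccc-2c(Nc2ccc(C(C)C)cc2)[nH]1`, gives 45700000 nM. Compound 2, `C=CCNc1nc(C)nc2[nH]ccc12`, gives 676000000 nM, which is the higher of the two numbers; the gap between them is beyond the scatter, so compound 2 is the weaker inhibitor of the pair. Within the data shown here, no step between them is counted, since they differ in more than one place.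

Compound 3, `Cc1nc(NCC(C)(C)C)c2cc[nH]c2n1`, has not yet been measured in this assay. It differs from compound 2 in one place: tert-butyl in place of vinyl on a saturated chain carbon bound to a nitrogen on an aromatic ring. Among the measured compounds shown here, no measured pair shows what this kind of change does here, so there is no step to lean on. The expectation for compound 3 therefore rests on compound 2 alone, and the step from compound 2 to compound 3 is expected to be small, a 1.4-fold lower number from compound 2 to compound 3 (0.13 log units; within the scatter), with no confident direction beyond the scatter. On that basis compound 3 is estimated at 500000000 nM in this assay, within a range from 100000000 nM to 2500000000 nM.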

Compound 3, half-maximal inhibitory concentration: 200000000 nM
The estimate for compound 3 lay 2.5-fold (0.40 log units) above the measured number, and the stated range covers the measured number.
By their numbers in this assay, from the lowest: compound 1; then compound 3; then compound 2.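

Read as a single change in this assay, allyl to neopentyl gives a 3.4-fold lower number from compound 2 to compound 3 (0.53 log units; beyond the scatter), which makes this the first step in the series to show that the number responds to what sits on a saturated chain carbon bound to a nitrogen on an aromatic ring. The change removes vinyl, with 2 heavy atoms and 1 double bond outside aromatic rings, and brings in tert-butyl, with 4 heavy atoms and no such double bond, so this one step cannot separate the gain in carbon from the loss of the double bond. No measurement shown here accounts for the step, and its direction is known for this single pair alone.

Going by these compounds, what remains open is whether an unbranched propyl chain, which would keep the saturation without the tert-butyl branching, or a cyclopropylmethyl group would move the number in the same way. On these data alone, it is also open how a longer chain, or a chain ending in an amine or a carboxylic acid, would behave at this position on the shared core.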